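Isopropyl for fluoro on the anilino ring of compound 2

The compounds below may be only part of what the source reports. "The series", "measured", "known", "first", "only" and "open" are said of these compounds alone.

Two compounds on the shared core have numbers in a functional assay on HCT-116 cells (Homo sapiens) for antiproliferative activity, read by MTT assay, with a stated time of 48 h; a higher number here means a weaker inhibitor, a lower number a stronger inhibitor. Compound 1 `NS(=O)(=O)c1ccc(Nc2nccc(Nc3nc4ccccc4s3)n2)cc1` gives 5170 nM in this assay. Compound 2 `Cc1cnc(Nc2ccc(F)cc2)nc1Nc1nc2ccccc2s1` returns only a limit of the assay, > 50000 nM, and not a number; this is the limit described by the limit of > 50000 nM in this assay, at which 1 of the 2 values shown sits. Compound 2 therefore stands at the weak end of what this assay reports, with no measured value below it to set a step against.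

Compound 3 `Cc1cnc(Nc2ccc(C(C)C)cc2)nc1Nc1nc2ccccc2s1` differs from compound 2 in one place: isopropyl in place of fluoro on an aromatic carbon. Within the data shown here, no measured pair shows this change on the series, so its size in this assay is open. Because compound 2 sits at the limit > 50000 nM, the step of an at least 1.4-fold lower number from compound 2 to compound 3 (0.15 log units; that floor lies within the scatter) is expected to be small, with a weak tendency toward a stronger inhibitor. Compound 3 is estimated at 35000 nM in this assay, with a range from 6000 nM to 200000 nM, and a fair chance that only a limit is reported again.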

Compound 3, half-maximal inhibitory concentration: > 50000 nM
Compound 3: only a limit was reported; the forecaster's own chance of this, stated with the estimate: 50%; at least 1.4-fold (0.15 log units) between middle value and limit.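

Compound 2 and compound 3 each give only a limit in this assay, so no step between them can be read: the limit of > 50000 nM in this assay, at which 2 of the 3 values shown sit.

The compounds shown leave open the size and direction of the change from fluoro to isopropyl on this aromatic ring.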